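This account rests on a few compounds, and the source may have more. Where it says the series, first, only, none or still open, it means among the compounds named here.

Two compounds built on a common core are compared first. Compound 1, `Cc1cnn(C(=O)N(C)CCN(C)Cc2cccc(OCc3ccccc3)c2)c1`, is tested in an assay on membranes from brain for binding affinity to Monoacylglycerol lipase ABHD6 (Mus musculus), read by fluorescence, with stated times of 1 h and 30 min (on this read-out lower numbers stand for stronger inhibition and higher numbers for weaker inhibition), where compound 1 gives 8300 nM. Compound 2, `CN(CCN(C)C(=O)n1cccn1)Cc1cccc(OCc2ccccc2)c1`, differs from compound 1 by hydrogen in place of methyl on an aromatic carbon. In this assay compound 2 gives 5500 nM. The step from the one to the other is a 1.5-fold lower number from compound 1 to compound 2 (0.18 log units; within the scatter).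

Compound 3, `Cc1cnn(C(=O)N(C)CCN(C)C(c2ccc(OCc3ccccc3)cc2)c2ccc(OCc3ccccc3)cc2)c1`, carries a different core, and the difference between its core and that of compound 1 is not broken down here. In this assay compound 3 gives > 1000000 nM, which is a limit of the assay and not a number; this is the limit of > 1000000 nM in this assay, at which 1 of the 3 values shown sits.

Compound 4, `CN(CCN(C)C(c1ccc(OCc2ccccc2)cc1)c1ccc(OCc2ccccc2)cc1)C(=O)n1cccn1`, is not yet measured. It differs from compound 3 by hydrogen in place of methyl on an aromatic carbon, the same change already seen between compound 1 and compound 2, at the same place. That earlier step was within the scatter, so the change is expected to move the number little on the core of compound 3 as well, meaning that compound 4 is expected to sit where compound 3 sits, with a number no higher from compound 3 to compound 4 (the limit leaves the size open). Compound 4 is therefore estimated at 1000000 nM in this assay, with a range expected from 300000 nM to 3000000 nM, and it is quite likely that only a limit and no number is reported for compound 4, just as for compound 3.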

Compound 4, half-maximal inhibitory concentration: > 1000000 nM
Compound 4 was reported as a limit; the forecaster's own chance of this, stated with the estimate: 85%; the middle value lies on the limit itself.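

In this assay compound 4 gives > 1000000 nM, which is a limit of the assay and not a number. Compound 3 also stands at a limit, so no step can be read between compound 3 and compound 4: the limit of > 1000000 nM in this assay, at which 2 of the 4 values shown sit.

The compounds shown leave open whether the change from 4-methyl-1H-pyrazol-1-yl to 1H-pyrazol-1-yl moves the number at all on the core of compound 3.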